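This account rests on a few compounds, and the source may have more. Where it says the series, first, only, none or still open, it means among the compounds named here.

Measured so far:
compound 1 `COc1cc(OCc2cccc(-c3ccc(C(F)(F)F)cn3)c2)c2cc(-c3cn4nc(OC)sc4n3)oc2c1`: > 2 h
compound 2 `COc1cc(OCc2csc(-c3ccc(C(N)=O)cc3)n2)c2cc(-c3cn4nc(OC)sc4n3)oc2c1`: 0.4 h

In an ADME assay on microsomes from liver (Rattus norvegicus) for metabolic stability (a higher number here means that the compound lasts longer, a lower number that the compound disappears faster), compound 1 sits at the limit of > 2 h in this assay, at which 1 of the 2 values shown sits, so only a limit and no number is known for it. Compound 2 gives 0.4 h in this assay. Within the data shown here, no single-point step links these two; their values show only that compound 1 lasts longer than compound 2. Compound 3 `COc1ccc(-c2cccc(COc3cc(OC)cc4oc(-c5cn6nc(OC)sc6n5)cc34)c2)nc1` is not yet measured and differs from compound 1 by methoxy in place of trifluoromethyl on an aromatic carbon. The step of an at least 1.3-fold lower number from compound 1 to compound 3 (0.12 log units; that floor lies within the scatter) is expected to be modest, leaning toward a shorter half-life but not clearly beyond the scatter. Compound 3 is therefore estimated at 1.5 h, between 0.6 h and 3 h.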

Compound 3, half-life: 0.317 h
Beside the measured number, compound 3's estimate is 4.7-fold (0.68 log units) above it; measured number below the stated range.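

This position is sensitive to what sits on it: in this assay, methoxy in place of trifluoromethyl on this aromatic carbon gives an at least 6.3-fold lower number from compound 1 to compound 3 (0.79 log units; beyond the scatter). Among these compounds, this single change is the first direct link among the compounds, and it separates them by more than the scatter. The value of compound 1 is a limit and not a number, so this step is only a floor: the limit of > 2 h in this assay, at which 1 of the 3 values shown sits.

The compounds shown leave open why the half-life shortens. They also leave open how a single fluorine atom, a nitrile or an ethoxy group on this carbon would compare.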